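The source may hold more compounds than are shown below. What is called first, only, known or untested is meant among the compounds shown, and "the series" means these compounds.

Measured so far in a physicochemical assay for solubility, read by HPLC, at pH 6.8; on this read-out higher numbers stand for higher solubility and lower numbers for lower solubility:
Compound 1 `CC(C)(C)c1cc(NC(=O)[C@@H]2CCCCN2C2CC2)no1` gives 38 ug/mL.
Compound 2 `CC(C)(C)c1cc(NC(=O)[C@@H]2CCCCN2CC2CCOCC2)no1` gives 72 ug/mL.
Compound 3 `CC(C)(C)c1cc(NC(=O)[C@@H]2CCCCN2C(=O)C2CCCCC2)no1` gives 6.4 ug/mL.

Compound 1 stands second highest of the three numbers. Its nearest neighbour is compound 2, reached by a 1.9-fold higher number from compound 1 to compound 2 (0.28 log units; within the scatter), a step that stays within the scatter; its furthest is compound 3, reached by a 5.9-fold lower number from compound 1 to compound 3 (0.77 log units; beyond the scatter). The compound not yet measured is compound 4 `CC(C)(C)c1cc(NC(=O)[C@@H]2CCCCN2C(=O)CC2CCOCC2)no1`. It differs from compound 1 in one place: ((oxan-4-yl)methyl)carbonyl in place of cyclopropyl on an amine nitrogen in a ring. Among the measured compounds shown here, two measured steps bear on this. The step of a 1.9-fold higher number from compound 1 to compound 2 (0.28 log units; within the scatter) puts an oxane-bearing group without a carbonyl on the amine nitrogen in the ring and stays within the scatter. The step of a 5.9-fold lower number from compound 1 to compound 3 (0.77 log units; beyond the scatter) puts a group carrying a carbonyl there and lowers the number beyond the scatter, and the step of an 11-fold lower number from compound 2 to compound 3 (1.05 log units; beyond the scatter) points the same way. Because the step of a 5.9-fold lower number from compound 1 to compound 3 (0.77 log units; beyond the scatter) lowers the number beyond the scatter and compound 4 likewise carries a carbonyl on that nitrogen, a lowering beyond the scatter is expected in this assay, perhaps a little smaller than for compound 3 because compound 2 gives 72 ug/mL. The expected step is a 2.5-fold lower number from compound 1 to compound 4 (0.40 log units; beyond the scatter). Compound 4 is therefore estimated at 15 ug/mL, with a range from 6 ug/mL to 38 ug/mL.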

Compound 4, solubility: 52 ug/mL
Compound 4: the middle estimate sits 3.5-fold (0.54 log units) below what was measured; measured number outside the range, above it.
By their numbers in this assay, from the lowest: compound 3; then compounds 1, 4 and 2 (each within the scatter of the next).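

The carbonyl on the amine nitrogen in the ring does not by itself bring a low number in this assay: with ((oxan-4-yl)methyl)carbonyl at this position, the results show a 1.4-fold higher number from compound 1 to compound 4 (0.14 log units; within the scatter) and a 1.4-fold lower number from compound 2 to compound 4 (0.14 log units; within the scatter), so compound 4 cannot be told apart from either compound that has no carbonyl there. The low number therefore goes with the cyclohexylcarbonyl group of compound 3 rather than with every carbonyl group at this nitrogen, as the change on the carbonyl carbon, (oxan-4-yl)methyl in place of cyclohexyl, gives an 8.1-fold higher number from compound 3 to compound 4 (0.91 log units; beyond the scatter). The data shown offer no measurement that explains why this change moves the number.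

Going by these compounds, compound 3 and compound 4 differ both in the ring oxygen of the oxane and in the extra methyl link, so it remains open which of these goes with the higher number, and cyclohexylmethyl or oxan-4-yl on the carbonyl carbon would pull the two apart. Also open, on these data alone, is where the number in this assay would fall with an amine or a carboxylic acid on that same carbonyl carbon.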